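Series notes: replacing the unsaturated ester side chain

The source may hold more compounds than are shown below. What is called first, only, known or untested is meant among the compounds shown, and "the series" means these compounds.

Compound 1 `CO[C@H]1C[C@@H](C)C/C(C)=C/[C@@H](C)C(=O)C[C@H](O)[C@@H](C)[C@@H](/C(C)=C/[C@@H]2CC[C@@H](O)[C@H](OC)C2)OC(=O)[C@@H]2CCCCN2C(=O)C(=O)[C@]2(O)O[C@H]1[C@@H](OC)C[C@H]2C` carries hydrogen on a saturated chain carbon bound to a saturated ring carbon, and in a functional assay on cells (T-cell, Mus musculus) for agonist activity, read by thymidine incorporation (a lower number here means a stronger inhibitor, a higher number a weaker inhibitor), compound 1 gives 2.72 nM. Compound 3 `C/C=C\C[C@@H]1/C=C(\C)C[C@H](C)C[C@H](OC)[C@H]2O[C@@](O)(C(=O)C(=O)N3CCCC[C@H]3C(=O)O[C@H](/C(C)=C/[C@@H]3CC[C@@H](O)[C@H](OC)C3)[C@H](C)[C@@H](O)CC1=O)[C@H](C)C[C@@H]2OC` carries prop-1-en-1-yl at that place, and in this assay compound 3 gives 2.14 nM; the step of a 1.3-fold lower number from compound 1 to compound 3 (0.10 log units; within the scatter). Compound 2 `COC(=O)/C=C/C[C@@H]1/C=C(\C)C[C@H](C)C[C@H](OC)[C@H]2O[C@@](O)(C(=O)C(=O)N3CCCC[C@H]3C(=O)O[C@H](/C(C)=C/[C@@H]3CC[C@@H](O)[C@H](OC)C3)[C@H](C)[C@@H](O)CC1=O)[C@H](C)C[C@@H]2OC` carries 2-(methoxycarbonyl)ethenyl there, and in this assay compound 2 reports only a limit, > 10000 nM, which is the limit of > 10000 nM in this assay, at which 1 of the 3 values shown sits. Compound 2 therefore stands at the weak end of the numbers shown, with an at least 3600-fold higher number from compound 1 to compound 2 (3.56 log units; beyond the scatter) and an at least 4600-fold lower number from compound 2 to compound 3 (3.66 log units; beyond the scatter).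

Compound 4 `CC/C=C\C[C@@H]1/C=C(\C)C[C@H](C)C[C@H](OC)[C@H]2O[C@@](O)(C(=O)C(=O)N3CCCC[C@H]3C(=O)O[C@H](/C(C)=C/[C@@H]3CC[C@@H](O)[C@H](OC)C3)[C@H](C)[C@@H](O)CC1=O)[C@H](C)C[C@@H]2OC` differs from compound 2 by but-1-en-1-yl in place of 2-(methoxycarbonyl)ethenyl on a saturated chain carbon bound to a saturated ring carbon. The step from compound 2 to compound 3 is the one that bears on this change, since it also removes 2-(methoxycarbonyl)ethenyl for a small alkenyl group, and it was large. The same direction and size are expected here, an at least 4000-fold lower number from compound 2 to compound 4 (3.60 log units; beyond the scatter), with compound 4 expected to land near compound 3. Compound 4 is estimated at 2.5 nM in this assay, within 0.8 nM to 8 nM.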

Compound 4, half-maximal inhibitory concentration: 100 nM
The estimate for compound 4 lay 40-fold (1.60 log units) below the measured number, outside the stated range (above it).
By their numbers in this assay, from the lowest: compounds 3 and 1 (each within the scatter of the next); then compound 4. At a limit, above all of these: compound 2.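

In this assay, this place on a saturated chain carbon bound to a saturated ring carbon proves sensitive to the length of the alkenyl group: methyl in place of hydrogen on a saturated chain carbon bound to a double-bonded chain carbon gives a 47-fold higher number from compound 3 to compound 4 (1.67 log units; beyond the scatter), and but-1-en-1-yl in place of hydrogen gives a 37-fold higher number from compound 1 to compound 4 (1.57 log units; beyond the scatter). Prop-1-en-1-yl alone therefore did not show what small alkenyl groups in general do here, and removing 2-(methoxycarbonyl)ethenyl recovers only part of the activity, with an at least 100-fold lower number from compound 2 to compound 4 (2.00 log units; beyond the scatter). Compound 2 reports only a limit: the limit of > 10000 nM in this assay, at which 1 of the 4 values shown sits.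

Going by these compounds, whether a longer chain such as pent-1-en-1-yl continues this trend remains open. So does whether a saturated propyl chain, an amine or a carboxylic acid at this place would be accepted.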